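The source may hold more compounds than are shown below. What is called first, only, known or untested is meant among the compounds shown, and "the series" means these compounds.

Working notes on the benzyloxy chalcone series.

Among the compounds with values here, the parent compound 1 `O=C(/C=C/c1ccccc1)c1ccc(OCc2ccccc2)cc1` is the only member with a number so far: in a functional assay on HCT-116 cells (Homo sapiens) for antiproliferative activity, read by sulforhodamine B assay, with a stated time of 3 days, tested at 50 uM (on this read-out lower numbers stand for a weaker effect and higher numbers for a stronger effect at the one concentration tested), compound 1 gives 33.8%. Within the data shown here, compound 2 `O=C(/C=C/c1ccc(F)cc1)c1ccc(OCc2ccccc2)cc1` carries the same core with a 4-fluorophenyl on the chain; in this assay compound 2 gives "not determined" (no result reported), so no single number stands for compound 2 and no step from compound 1 to compound 2 can be stated.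

Compound 3 `COc1cccc(/C=C/C(=O)c2ccc(OCc3ccccc3)cc2)c1` is next. Relative to compound 2 the change is 3-methoxyphenyl in place of 4-fluorophenyl on a double-bonded chain carbon bound to a double-bonded chain carbon. Among the measured compounds shown here, the 3-methoxyphenyl enters with one hydrogen-bond acceptor where the 4-fluorophenyl had none; no comparable step shows what that is worth. With only the value of compound 1 as anchor, a shift within the scatter of this assay, in either direction, is expected rather than a large one. For compound 3 the inhibition in this assay is estimated at 38%, within 15% to 65%.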

Compound 3, a percentage reported as inhibition, at one concentration (the size of the read-out at that concentration, not a potency): 76%
For compound 3 the middle estimate is 38 percentage points below the measured one; measured number outside the range, above it.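

The 3-methoxyphenyl on the double-bonded chain carbon gives the series its first readable step: in this assay methoxy in place of hydrogen on an aromatic carbon amounts to a number 42.2 percentage points higher from compound 1 to compound 3 (beyond the scatter) on the shared core. This place on the chain thus responds strongly to a single added group, which compound 1 alone could not show, while the step from compound 2 to compound 3 cannot be read and the 4-fluorophenyl stays unplaced. Nothing on hand bears on the reason for the size of this step.

Still open, on these data alone, is whether the gain is specific to the methoxy, or whether a hydroxyl, an amine or a carboxylic acid in its place would keep, lose or extend it. Also open, as far as these compounds go, is whether the gain persists when the benzyloxy group of the core is replaced by a longer chain.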